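Terminal amine substituent exchange: oxane to pyridine

This account rests on a few compounds, and the source may have more. Where it says the series, first, only, none or still open, it means among the compounds named here.

Measured compounds:
compound 1 `c1ccc(CNCCCCN(C[C@H]2Cc3ccccc3CN2)[C@H]2CCCc3cccnc32)cc1` — 20.1 nM
compound 2 `C(=C/CN(C[C@H]1Cc2ccccc2CN1)[C@H]1CCCc2cccnc21)\CNCC1CCOCC1` — 24.2 nM

In a functional assay on cells for antagonist activity at C-X-C chemokine receptor type 4 (Homo sapiens), read by fluorescence and calcium flux, with stated times of 25 min and 90 s (on this read-out higher numbers stand for weaker inhibition and lower numbers for stronger inhibition), compound 2 gives the higher of the two numbers, with compound 1 nearest at a difference within the scatter. For the measured compounds named here, the one measured step at this position, a 1.2-fold higher number from compound 1 to compound 2 (0.08 log units; within the scatter), exchanged a carbon-only aromatic ring for a non-aromatic oxygen ring without moving the number beyond the scatter. Compound 3 `C(=C/CN(C[C@H]1Cc2ccccc2CN1)[C@H]1CCCc2cccnc21)\CNCc1cccnc1` carries pyridin-3-yl in place of oxan-4-yl on a saturated chain carbon bound to an amine nitrogen. Going by the values given here, that earlier step is the only one bearing on this change, and it was flat, so no shift beyond the scatter is expected: a 1.1-fold lower number from compound 2 to compound 3 (0.04 log units; within the scatter). Compound 3 is estimated at 22 nM, within 10 nM to 50 nM.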

Compound 3, half-maximal inhibitory concentration: 92.8 nM
Compound 3: middle estimate off by 4.2-fold (0.63 log units), on the low side, and the stated range ends below it.
By their numbers in this assay, from the lowest: compounds 1 and 2 (each within the scatter of the next); then compound 3.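

In this assay, the ring on a saturated chain carbon bound to an amine nitrogen does matter: pyridin-3-yl in place of oxan-4-yl gives a 3.8-fold higher number from compound 2 to compound 3 (0.58 log units; beyond the scatter), whereas the earlier ring exchange stayed within the scatter. An aromatic ring as such does not account for this, since the group with the carbon-only aromatic ring differs from the pyridine-bearing group by a 4.6-fold higher number from compound 1 to compound 3 (0.66 log units; beyond the scatter). No supporting data explain the shift. On these data alone, whether pyridin-2-yl, pyridin-4-yl or piperidin-4-yl would behave like pyridin-3-yl here remains open.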